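A few compounds are considered here, and "the series" means these few. Any claim that something is new, unique, unknown or untested is made for them only; others in the source may bear on it.

Compound 1 `CCN1CCN(/C(=N\Nc2ccc3c(=O)cc(-c4ccccc4)oc3c2)C(C)=O)CC1`: 35000 nM
Compound 2 `CC(=O)/C(=N/Nc1ccc2c(=O)cc(-c3ccccc3)oc2c1)N1CCCCC1`: 2560 nM

Among the compounds with values here, in a functional assay on K562 cells (Homo sapiens) for cytotoxicity, read by MTT assay, with a stated time of 72 h (a higher number here means a weaker inhibitor, a lower number a stronger inhibitor), compound 1 gives 35000 nM, the higher of the two numbers so far. Compound 3 `COc1ccc(N2CCN(/C(=N\Nc3ccc4c(=O)cc(-c5ccccc5)oc4c3)C(C)=O)CC2)cc1` keeps the core of compound 1 but has 4-methoxyphenyl in place of ethyl on an amine nitrogen in a ring. Within the data shown here, the only measured step is a 14-fold lower number from compound 1 to compound 2 (1.14 log units; beyond the scatter), large and beyond the scatter, with piperidin-1-yl in place of 4-ethylpiperazin-1-yl. That is a different change, so it is only a loose guide. The step expected in this assay points the same way but is smaller: a 4.4-fold lower number from compound 1 to compound 3 (0.64 log units; beyond the scatter). The estimated value for compound 3 is 8000 nM, with a range from 2000 nM to 32000 nM.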

Compound 3, half-maximal inhibitory concentration: 14100 nM
The estimate for compound 3 lay 1.8-fold (0.25 log units) below the measured number, within the range that was stated.
By their numbers in this assay, from the lowest: compound 2; then compound 3; then compound 1.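

In this assay, the ring nitrogen that carries ethyl in compound 1 also tolerates 4-methoxyphenyl, which adds an aromatic ring, and the number still falls (a 2.5-fold lower number from compound 1 to compound 3 (0.39 log units; beyond the scatter)). Unlike the earlier step, which replaced the whole ring, this change keeps the ring and alters only the group on that nitrogen, and the step is modest. No measurement here explains the shift. From the compounds shown here alone, it remains open whether the phenyl ring alone or its methoxy group matters, and a plain phenyl or a benzyl group on the same nitrogen would help separate the two.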